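This account rests on a few compounds, and the source may have more. Where it says the series, first, only, none or still open, it means among the compounds named here.

Measured compounds:
- compound 1 `CCCCc1ccc(NC(=O)C2CCN(C/C=C/c3ccccc3)CC2)cc1`: in a functional assay on A549 cells (Homo sapiens) for inhibition, read by MTT assay, with a stated time of 72 h (a lower number here means a stronger inhibitor, a higher number a weaker inhibitor), compound 1 gives 5910 nM
- compound 2 `COc1ccc(NC(=O)C2CCN(C/C=C/c3ccccc3)CC2)cc1`: in this assay compound 2 gives 83800 nM
- compound 3 `CN1CCN(c2ccc(NC(=O)C3CCN(C/C=C/c4ccccc4)CC3)cc2)CC1`: in this assay compound 3 gives 19900 nM

Compound 2 stands at the highest number of the three in this assay; compound 3 is nearest, compound 1 furthest, with steps a 4.2-fold lower number from compound 2 to compound 3 (0.62 log units; beyond the scatter) and a 14-fold higher number from compound 1 to compound 2 (1.15 log units; beyond the scatter), both beyond the scatter. The remaining step is a 3.4-fold higher number from compound 1 to compound 3 (0.53 log units; beyond the scatter).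

Compound 4 `O=C(NCc1ccccc1)C1CCN(C/C=C/c2ccccc2)CC1` is not yet measured. It differs from compound 2 as follows: benzyl in place of 4-methoxyphenyl on an amide-type nitrogen. This change sits on the amide nitrogen itself and replaces the whole aromatic group, whereas every measured step in the series changes only the group on an aromatic carbon of that ring. For the measured compounds named here, no measured step therefore bears directly on it. Going by the values given here, what the data do show is that compound 2 carries the only methoxy group and gives the highest number, and that the two compounds without it give lower numbers by modest to large steps. Compound 4 also has no methoxy group, so a lower number is expected in this assay, but with wide uncertainty as the change is of a different kind. The estimated step of a 4.2-fold lower number from compound 2 to compound 4 (0.62 log units; beyond the scatter) is taken as modest. For compound 4 the expected value is 20000 nM, within 4000 nM to 100000 nM.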

Compound 4, half-maximal inhibitory concentration: > 100000 nM
Compound 4 gave a limit, no number (the forecaster's own chance of this, stated with the estimate: 15%); at least 5.0-fold (0.69 log units) between middle value and limit.
By their numbers in this assay, from the lowest: compound 1; then compound 3; then compound 2. At a limit, above all of these: compound 4.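

In this assay, for the compounds shown here, compound 4 gives > 100000 nM as a limit and not a number, and it is the only compound of the series to stop there: the limit of > 100000 nM in this assay, at which 1 of the 4 values shown sits. Benzyl in place of 4-methoxyphenyl on an amide-type nitrogen gives an at least 1.1-fold higher number from compound 2 to compound 4 (0.07 log units; that floor lies within the scatter) and, with that floor inside the scatter, compound 4 cannot be set apart from compound 2, although this is the first result that concerns the group on the amide nitrogen rather than a group on an aromatic carbon. Compound 4 also carries no methoxy group and shows no lower number than compound 2, so the absence of methoxy alone does not account for the lower numbers of compound 1 and compound 3.

Open, from the compounds shown here alone, is whether butyl or 4-methylpiperazin-1-yl on the ring of the benzyl group would bring the number down as they do on the 4-substituted phenyl amides, and whether an unsubstituted phenyl on the amide nitrogen would behave like compound 2 or compound 4. Also open, going by these compounds, is how a longer chain such as hexyl, or a primary amine, would compare with butyl on the aromatic carbon.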